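Oxygen-to-sulfur swap in the ring beside the sulfonyl chain

The source may report more compounds than this note shows. Statements on the series, on what has been measured and on what is new or still open speak of the compounds shown alone.

Compound 1 `O=S(=O)(CC1=NCCO1)C1C(c2ccc(Cl)cc2)=NN(c2ccccc2)C1c1ccc(Cl)cc1` carries a sulfonyl-linked five-membered ring and two chlorophenyl groups on its core. In a functional assay, tested at 50 ug/mL (a lower number here means a weaker effect, a higher number a stronger effect of the compound at the concentration tested), compound 1 is reported as "not active" (no number reported), so no single number is available for it. Compound 3 `O=S(=O)(CC1=NCCO1)C1=NNCC1c1ccccc1` shares the sulfonyl-linked ring on a smaller core, and in this assay compound 3 is likewise reported as "not active" (no number reported). Only compound 2 `COc1ccc(-c2nn(-c3ccccc3)c(-c3ccc(C)cc3)c2S(=O)(=O)CC2=NCCO2)cc1`, with a methoxyphenyl and a methylphenyl on the core, gives a number: in this assay compound 2 reaches 67.6%. Among the compounds with values here, no step between two measured compounds that differ in one place is available in this set, so the weight of any single change has not been measured here.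

Compound 4 `O=S(=O)(CC1=NCCS1)C1C(c2ccc(Cl)cc2)=NN(c2ccccc2)C1c1ccc(Cl)cc1` differs from compound 1 by a single exchange: a group of 5 heavy atoms (3 carbon, 1 nitrogen, 1 sulfur; one five-membered non-aromatic ring with 2 hetero atoms) in place of a group of 5 heavy atoms (3 carbon, 1 nitrogen, 1 oxygen; one five-membered non-aromatic ring with 2 hetero atoms), on a saturated chain carbon bound to a sulfonyl sulfur. The change keeps the ring size and the count of hetero atoms, and the rest of the structure is the same as in compound 1. Since compound 1 shows no measurable effect in this assay, the expectation for compound 4 is a step of no more than the usual scatter, in no particular direction, with a fair chance that compound 4 is again reported without a number. Compound 4 is therefore estimated at 10% in this assay, with a range from 0% to 35%.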

Compound 4, a percentage reported as activity, at one concentration (the size of the read-out at that concentration, not a potency): "not active" (no number reported)
For compound 4 the study gives words and no number; no gap can be computed for the estimate.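

Compound 4, like compound 1, is reported in this assay without a number, so no step can be read from compound 1 to compound 4. Nothing available here bears on this result. Open, on these data alone, is whether the oxygen-to-sulfur exchange alters the read-out on a core with a numerical result, such as compound 2 at 67.6%.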